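Bromo Substitution on a Tricyclic Core: Two Parallel Cases

A few compounds are considered here, and "the series" means these few. Any claim that something is new, unique, unknown or untested is made for them only; others in the source may bear on it.

The measured compounds and their results:

Compound 1, `Cn1cc(C2CCN=C(N)N2)c2ccccc21`: 1710 nM
Compound 2, `Cn1cc(C2CCN=C(N)N2)c2ccc(Br)cc21`: 8790 nM
Compound 3, `CC(=O)/N=C1\NCCC(c2cn(C)c3ccccc23)N1`: 14400 nM

In a functional assay on MDA-MB-231 cells (Homo sapiens) for cytotoxicity, read by sulforhodamine B assay, with a stated time of 72 h (on this read-out lower numbers stand for stronger inhibition of growth and higher numbers for weaker inhibition of growth), compound 1 gives 1710 nM. Compound 2 carries one change relative to compound 1, described as bromo in place of hydrogen on an aromatic carbon. In this assay compound 2 gives 8790 nM, and the step is a 5.1-fold higher number from compound 1 to compound 2 (0.71 log units; beyond the scatter).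

Compound 3 rests on a different core; the difference between the two cores is not broken down here. Compound 3 gives 14400 nM in this assay, which is the highest of the three numbers, though the gap to compound 2 lies within the usual scatter, so no order between those two can be claimed.

Compound 4, `CC(=O)/N=C1\NCCC(c2cn(C)c3cc(Br)ccc23)N1`, has not been measured. It stands to compound 3 as compound 2 stands to compound 1: the change is bromo in place of hydrogen on an aromatic carbon. The two descriptions of the place are the same word for word, so this is the same change made on a second core.

Among the compounds with values here, the only guide is the measured pair. Because a 5.1-fold higher number from compound 1 to compound 2 (0.71 log units; beyond the scatter) moved the number upward beyond the scatter, a step of similar direction and size is expected from compound 3 to compound 4, namely a 4.2-fold higher number from compound 3 to compound 4 (0.62 log units; beyond the scatter). Whether the second core answers the change in the same way is not known from these three compounds alone, so the range is kept wide. Compound 4 is therefore expected to give about 60000 nM in this assay, estimated to lie between 20000 nM and 180000 nM.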

Compound 4, concentration for 50% growth inhibition: 8020 nM
For compound 4 the middle estimate is 7.5-fold (0.87 log units) above the measured one; the whole stated range lies above it.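

In this assay, bromo in place of hydrogen on an aromatic carbon gives a 1.8-fold lower number from compound 3 to compound 4 (0.25 log units; within the scatter), so on this core the change leaves no effect that can be told apart from the ordinary spread of repeated measurements. Set beside the earlier step, this shows that the response to the change does not carry over unchanged from one core to the other in this series: the same change on two cores in this assay, a 5.1-fold higher number (0.71 log units; beyond the scatter) from compound 1 to compound 2 and a 1.8-fold lower number (0.25 log units; within the scatter) from compound 3 to compound 4, 9.2-fold (0.97 log units) apart, beyond the scatter of two such steps. It does not show why the two cores part ways, and with a single pair on each core, it cannot say whether the same split would appear for any other group or at any other place on the ring.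

The compounds shown leave open how a different group on the same aromatic carbon, such as chloro, methoxy or an amine, would behave on each of the two cores. Also open, as far as these compounds go, is whether a carboxylic acid or a longer chain there would bring either core to a lower number than compound 1 gives, at 1710 nM, and whether the two cores would then respond alike.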